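This account rests on a few compounds, and the source may have more. Where it says the series, first, only, none or still open, it means among the compounds named here.

Working notes on the series.

In an ADME assay on MDCK cells (Canis lupus familiaris) for cytotoxicity, read by microscopy, with a stated time of 48 h (a lower number here means that less compound is tolerated, a higher number that more compound is tolerated), compound 1 `C[C@H]1[C@H](NCc2ccsc2)C[C@H]2C[C@@H]1C2(C)C` gives 50000 nM, and compound 2 `C[C@H]1[C@H](NCc2sccc2Br)C[C@H]2C[C@@H]1C2(C)C` gives 50000 nM; the step of no change at the digits printed from compound 1 to compound 2 (within the scatter) is flat. Compound 3 `Cc1csc(CN[C@@H]2C[C@H]3C[C@@H]([C@H]2C)C3(C)C)c1` gives 12500 nM in this assay, the lowest of the three numbers. Both steps onto it, a 4.0-fold lower number from compound 1 to compound 3 (0.60 log units; beyond the scatter) and a 4.0-fold lower number from compound 2 to compound 3 (0.60 log units; beyond the scatter), are modest and beyond the scatter, so compound 3 is the least tolerated of the three measured compounds, with compound 1 and compound 2 standing together at a higher number.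

Compound 4 `CCCCc1csc(CN[C@@H]2C[C@H]3C[C@@H]([C@H]2C)C3(C)C)c1` differs from compound 3 by propyl in place of hydrogen on a saturated chain carbon bound to an aromatic carbon. None of the three measured steps is of this kind: each of them exchanges one aromatic group for another on the carbon bound to the amine nitrogen, none grows a chain on the 4-methylthiophen-2-yl group. For the measured compounds named here, the only guidance is that the 4-methylthiophen-2-yl compound 3 sits lowest, and that the two exchanges onto it moved the number by a modest amount. Compound 4 is therefore expected to stay close to compound 3 in this assay, with the step of a 1.6-fold lower number from compound 3 to compound 4 (0.19 log units; within the scatter) estimated to be small or within the scatter, and if anything toward a lower number. The estimate for compound 4 in this assay is 8000 nM, expected between 3000 nM and 25000 nM.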

Compound 4, minimum cytotoxic concentration: 12500 nM
For compound 4 the middle estimate is 1.6-fold (0.19 log units) below the measured one, and the stated range covers the measured number.
By their numbers in this assay, from the lowest: compounds 3 and 4 (each within the scatter of the next); then compounds 1 and 2 (each within the scatter of the next).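

Propyl in place of hydrogen on a saturated chain carbon bound to an aromatic carbon, which cut one bond further out reads methyl to butyl, gives in this assay the step of no change at the digits printed from compound 3 to compound 4 (within the scatter), so this place on the thiophene takes the longer chain with no change in the number read. For the compounds shown here, the earlier steps exchanged only one aromatic group for another on the carbon bound to the amine nitrogen, and none of them gave a reading for a change in chain length at this place. No measurement on hand bears on what lies behind this flat step.

Still open, going by these compounds, is whether a longer chain such as hexyl, or a chain carrying an amine or a carboxylic acid, would leave the number in this assay just as unchanged, or whether the flat reading holds only as far as butyl. Also open, on these data alone, is whether the same change from hydrogen to propyl would read alike in a compound with another thiophene group on the chain carbon bound to the amine nitrogen.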